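Ring Amines on the Amide Carbonyl of Inactive Compounds

The source may report more compounds than this note shows. Statements on the series, on what has been measured and on what is new or still open speak of the compounds shown alone.

The measured compounds, each tested in an assay on isolated protein for inhibition of thyroid hormone receptor beta (Homo sapiens), read by fluorescence polarization; a lower number here means a stronger inhibitor, a higher number a weaker inhibitor:
compound 1 `CC(C)N(C(=O)CCNC(=O)c1ccc(S(C)(=O)=O)c([N+](=O)[O-])c1)C(C)C`, reported only as the limit > 60000 nM
compound 2 `CS(=O)(=O)c1ccc(C(=O)NCCC(=O)N2CCc3ccccc3C2)cc1[N+](=O)[O-]`, reported only as the limit > 60000 nM
compound 3 `CS(=O)(=O)c1ccc(C(=O)NCCC(=O)N2CCCCC2)cc1[N+](=O)[O-]`, reported only as the limit > 60000 nM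

Compound 3 stands at a limit in this assay and not at a number. The same holds for every value shown, all resting at the limit of > 60000 nM in this assay, at which 3 of the 3 values shown sit. For this reason none of the steps between the measured compounds can be read: a step that the two limits leave unreadable from compound 1 to compound 2, a step that the two limits leave unreadable from compound 1 to compound 3 and a step that the two limits leave unreadable from compound 2 to compound 3 are each hidden behind the two limits.

Compound 4 `CS(=O)(=O)c1ccc(C(=O)NCCC(=O)N2CCCc3ccccc32)cc1[N+](=O)[O-]` is not yet measured. It differs from compound 3 in one place: 1,2,3,4-tetrahydroquinolin-1-yl in place of piperidin-1-yl on a carbonyl carbon. The closest measured comparison is compound 2, where a ring amine carrying a fused aromatic ring in place of piperidin-1-yl also left the value at a limit, though the size of that step is not readable.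

With nothing measured below the limit, the step that the limit leaves unreadable from compound 3 to compound 4 is expected to be no more than the scatter, and compound 4 is expected most likely to return a limit again. Compound 4 is estimated at 100000 nM, within a range from 30000 nM to 400000 nM.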

Compound 4, half-maximal inhibitory concentration: > 60000 nM
Compound 4: no number, only a limit; the forecaster's own chance of this, stated with the estimate: 85%; the middle value is on the limit's open side.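

In this assay, compound 4 gives only a limit, > 60000 nM. Its steps from compound 1, compound 2 and compound 3 therefore cannot be read, and all four compounds rest at the same limit: the limit of > 60000 nM in this assay, at which 4 of the 4 values shown sit.

The compounds shown leave open whether any amine on this carbonyl carbon gives a measurable value in this assay, and how far these four compounds differ.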